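A Methylpyridyl Replacement for Isothiazolyl in a Bombesin Series

The compounds below may be only part of what the source reports. "The series", "measured", "known", "first", "only" and "open" are said of these compounds alone.

Measured compounds:
compound 1 `c1ccc(-c2ccc(CCc3nc(CC4CCCC4)c[nH]3)cc2)nc1` with 425 nM
compound 2 `CCC(C)(C)Cc1c[nH]c(CCc2ccc(-c3cnsc3)cc2)n1` with 44 nM

Of the compounds shown here, two have been measured in a functional assay on HEK293 cells for agonist activity at Bombesin receptor subtype-3 (Homo sapiens), read by luminescence and calcium flux, with a stated time of 10 min; a lower number here means that less compound is needed, a higher number that more compound is needed for the effect. Compound 1 `c1ccc(-c2ccc(CCc3nc(CC4CCCC4)c[nH]3)cc2)nc1` gives 425 nM, while compound 2 `CCC(C)(C)Cc1c[nH]c(CCc2ccc(-c3cnsc3)cc2)n1` gives 44 nM, the lower of the two numbers; the gap between them is beyond the usual scatter, though the two structures differ in more than one place, so nothing can be tied to a single change.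

Compound 3 `CCC(C)(C)Cc1c[nH]c(CCc2ccc(-c3cccc(C)n3)cc2)n1` keeps the side chain of compound 2 and changes the aromatic group: 6-methylpyridin-2-yl in place of 1,2-thiazol-4-yl on an aromatic carbon. Compound 1 already carries a related six-membered ring and sits higher than compound 2, but its side chain differs too. A modest step upward from compound 2 is expected, a 2.5-fold higher number from compound 2 to compound 3 (0.40 log units; beyond the scatter), near the edge of the scatter. Compound 3 is therefore estimated at 110 nM, within a range of 35 nM to 400 nM.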

Compound 3, half-maximal effective concentration: 105 nM
Compound 3: middle estimate off by 1.0-fold (0.02 log units), on the high side, and the stated range covers the measured number.
By their numbers in this assay, from the lowest: compound 2; then compound 3; then compound 1.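

In this assay, for the compounds shown here, putting 6-methylpyridin-2-yl in place of 1,2-thiazol-4-yl on this aromatic carbon, para to a large group, gives a 2.4-fold higher number from compound 2 to compound 3 (0.38 log units; beyond the scatter), and this is the only comparison here that can be tied to one place. It shows that the aromatic group at this position affects the number, although replacing a five-membered aromatic ring with 2 hetero atoms by a six-membered one with 1 hetero atom and a methyl group produces only a modest step. No measurement bears on why the number moves.

Ring size, hetero atoms and the methyl group all change together, so the compounds shown leave open how much of the step belongs to each. On these data alone, it also remains open how a phenyl ring or a 6-methoxypyridin-2-yl group would read at this position with the side chain of compound 2.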